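A Dimethylamino Group Replaces Ethyl in Compound 3

This account rests on a few compounds, and the source may have more. Where it says the series, first, only, none or still open, it means among the compounds named here.

In an ADME assay on BaF3 cells (Mus musculus) for cytotoxicity, read by CellTiter-Glo and CCK-8 assay, with a stated time of 72 h (a lower number here means a stronger inhibitor of growth, a higher number a weaker inhibitor of growth), compound 1 `C=CS(=O)(=O)NCc1ccc(C(=O)Nc2ccc(C)c(Nc3nccc(-c4cccnc4)n3)c2)cc1` gives 7710 nM as its reading. Compound 2 `CCCC(=O)N(CCN(C)C)Cc1ccc(C(=O)Nc2ccc(C)c(Nc3nccc(-c4cccnc4)n3)c2)cc1` gives > 10000 nM as a limit and not a number. Among the measured compounds shown here, the one measured step (an at least 1.2-fold higher number from compound 1 to compound 2 (0.11 log units; that floor lies within the scatter)) concerns a different group, so it offers little guidance for the next change. Compound 3 `Cc1ccc(NC(=O)c2ccc(CN(CCN(C)C)C(=O)CN(C)C)cc2)cc1Nc1nccc(-c2cccnc2)n1` differs from compound 2 as follows (dimethylamino in place of ethyl on a saturated chain carbon bound to a carbonyl carbon): dimethylamino in place of ethyl on a saturated chain carbon bound to a carbonyl carbon. The estimated step that the limit leaves unreadable from compound 2 to compound 3 is expected to stay within the scatter, with no clear direction. Compound 3 is estimated at 11000 nM (expected range 5000 nM to 25000 nM).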

Compound 3, concentration for 50% growth inhibition: > 10000 nM
Compound 3 was reported as a limit; the forecaster's own chance of this, stated with the estimate: 65%; the middle value does not contradict the limit.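

In this assay compound 3 gives > 10000 nM as a limit and not a number. The full replacement of the (vinylsulfonyl)amino group shows an at least 1.2-fold higher number from compound 1 to compound 3 (0.11 log units; that floor lies within the scatter) and so sets no order between the two compounds. The change of ethyl to dimethylamino on a saturated chain carbon bound to a carbonyl carbon cannot be read, because both compounds stop at the same limit: the limit of > 10000 nM in this assay, at which 2 of the 3 values shown sit. From the compounds shown here alone, whether a carboxylic acid or a longer chain at this carbon would give a reading that is a number remains open.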